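Methyl to Trifluoromethyl Across Two Cores

The compounds below may be only part of what the source reports. "The series", "measured", "known", "first", "only" and "open" are said of these compounds alone.

The measured compounds:
compound 1, `CCOC(=O)N1CCC(=NNC(=O)c2ccc(C)cc2)CC1`, which in a functional assay for inhibition, read by spectrophotometry, with a stated time of 120 min (a higher number here means a weaker inhibitor, a lower number a stronger inhibitor), gives 52500 nM
compound 2, `CCOC(=O)N1CCC(=NNC(=O)c2ccc(C(F)(F)F)cc2)CC1`, where compound 2 gives 49300 nM
compound 3, `Cc1ccc(C(=O)NN=C2CC(c3ccccc3)NC(c3ccccc3)C2)cc1`, where compound 3 gives 69000 nM

Compound 1 and compound 2 share one core and differ only by trifluoromethyl in place of methyl on an aromatic carbon. That change produced a 1.1-fold lower number from compound 1 to compound 2 (0.03 log units; within the scatter), so in this assay the two behave as one. Compound 3 is built on a second core; the difference between the core of compound 1 and the core of compound 3 is not broken down here. Its value sits beside those of compound 1 and compound 2 within the usual scatter, so no ordering among the three can be drawn from these numbers.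

Compound 4, `O=C(NN=C1CC(c2ccccc2)NC(c2ccccc2)C1)c1ccc(C(F)(F)F)cc1`, stands to compound 3 as compound 2 stands to compound 1: it carries trifluoromethyl in place of methyl on an aromatic carbon. The change is the same one, and it sits at the same kind of place, on an aromatic carbon of a six-membered aromatic ring of carbon only, para to a large group. It occurs twice among these four compounds.

The expectation for compound 4 therefore rests on a single prior example. Compound 4 is expected to move by a 1.1-fold lower number from compound 3 to compound 4 (0.04 log units; within the scatter), a step of about the same small size, because the same change gave a 1.1-fold lower number from compound 1 to compound 2 (0.03 log units; within the scatter). Whether the second core answers in the same way is not known, and only compound 1 and compound 2 speak to it. With that caution, compound 4 is estimated at 63000 nM in this assay, within an expected range from 30000 nM to 130000 nM.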

Compound 4, half-maximal inhibitory concentration: 55300 nM
Compound 4: the middle estimate sits 1.1-fold (0.06 log units) above what was measured; low and high end bracket the measured number.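

In this assay, trifluoromethyl in place of methyl on an aromatic carbon of the second core gave a 1.2-fold lower number from compound 3 to compound 4 (0.10 log units; within the scatter), so on this core, as on the first, the swap leaves no readable mark on the number. Set side by side, the two steps agree, and the change carried from one core to the other without any visible difference in its size: the same change on two cores in this assay, a 1.1-fold lower number (0.03 log units; within the scatter) from compound 1 to compound 2 and a 1.2-fold lower number (0.10 log units; within the scatter) from compound 3 to compound 4, 1.2-fold (0.07 log units) apart, within the scatter of two such steps. This shows that in these four compounds the swap is silent on both cores, but it does not show that the two cores respond alike in general, since two steps that are both too small to read cannot reveal whether a real effect would transfer, and two cores are no basis for a rule about a third.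

The compounds shown leave open whether any group at this place can move the number at all, as only methyl and trifluoromethyl appear there, and what a carboxylic acid, an amine or a longer chain would do in their stead remains unknown. Also open, on these data alone, is whether a group that did shift the number on one core would shift it to the same extent on the other.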